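A few compounds are considered here, and "the series" means these few. Any claim that something is new, unique, unknown or untested is made for them only; others in the source may bear on it.

Measured in a functional assay on CHO cells for antagonist activity at prostaglandin E2 receptor EP3 subtype (Homo sapiens), read by cAMP accumulation, with a stated time of 30 min; a lower number here means a stronger inhibitor, a higher number a weaker inhibitor:
compound 1, `CCC(/C=C1\OC(=O)NC1=O)(CC)c1ccc(-c2ccc3cc(F)cc(F)c3c2)[nH]c1=O`: 45 nM
compound 2, `CC(C)C(c1ccc(-c2ccc3cccc(F)c3c2)[nH]c1=O)C1SC(=O)NC1=O`: 110 nM

Among these two numbers, compound 2 holds the higher one; its only neighbour is compound 1, whose number is lower by a gap that lies beyond the usual scatter of repeated measurements. The two compounds differ from each other in more than one place, so no single measured step can be read from them.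

Compound 3, `CC(C)C(CC1C(=O)NC(=O)N1C)c1ccc(-c2ccc3cccc(F)c3c2)[nH]c1=O`, has not yet been tested in this assay. It is compound 2 with one change: (3-methyl-2,5-dioxoimidazolidin-4-yl)methyl in place of 2,4-dioxo-1,3-thiazolidin-5-yl on a saturated chain carbon bound to an aromatic carbon and a saturated chain carbon. The group that leaves sits directly on that chain carbon; the group that enters is the larger of the two by the counted heavy atoms and carries one hydrogen-bond acceptor fewer.

For the measured compounds named here, no measured pair shows what such a change does, so the expectation rests on the change alone and is held loosely. The step of a 2.7-fold higher number from compound 2 to compound 3 (0.44 log units; beyond the scatter) is expected to be a moderate rise, somewhat beyond the scatter, toward a weaker inhibitor. Compound 3 is therefore estimated at 300 nM, within a range of 80 nM to 1500 nM.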

Compound 3, half-maximal inhibitory concentration in the prostaglandin E2 receptor EP3 subtype assay: 65 nM
Compound 3: middle estimate off by 4.6-fold (0.66 log units), on the high side; the whole stated range lies above it.
By their numbers in the prostaglandin E2 receptor EP3 subtype assay, from the lowest: compounds 1, 3 and 2 (each within the scatter of the next, the first and the last beyond it).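

For the compounds shown here, in the prostaglandin E2 receptor EP3 subtype assay, placing (3-methyl-2,5-dioxoimidazolidin-4-yl)methyl instead of 2,4-dioxo-1,3-thiazolidin-5-yl on the saturated chain carbon gives a 1.7-fold lower number from compound 2 to compound 3 (0.23 log units; within the scatter), so this is the first direct sign that this position can carry either group, even though the entering group is the larger by counted heavy atoms and has one hydrogen-bond acceptor fewer, with no difference beyond the scatter. In a physicochemical assay for solubility, in phosphate buffer, measured as kinetic solubility (on this read-out lower numbers stand for lower solubility and higher numbers for higher solubility), compound 2 gives 20100 nM and compound 3 gives 33600 nM, two values within the usual scatter of each other, so the pair cannot be told apart on this read-out either. No measurement shown here explains why the two groups give such similar results.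

Compound 1 differs from compound 2 and compound 3 in more than one place, and the steps to it cannot be read. As far as these compounds go, it remains open whether this position would accept a group outside this pair of five-membered rings, such as a carboxylic acid or a simple primary amide, on the same saturated chain carbon.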